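A few compounds are considered here, and "the series" means these few. Any claim that something is new, unique, unknown or untested is made for them only; others in the source may bear on it.

Measured so far in an assay for inhibition of 3-hydroxy-3-methylglutaryl-coenzyme A reductase (Rattus norvegicus); a lower number here means a stronger inhibitor, a higher number a weaker inhibitor:
- compound 1 `O=C1C[C@H](O)C[C@@H](/C=C/c2c(Cl)cc(Cl)cc2-c2ccc(Cl)c(Cl)c2)O1`: 25 nM
- compound 2 `Cc1cc(C)c(/C=C/[C@@H]2C[C@@H](O)CC(=O)O2)c(-c2ccc(F)cc2)c1`: 13 nM
- compound 3 `O=C1C[C@H](O)C[C@@H](/C=C/c2ccccc2-c2ccccc2)O1`: 3000 nM

Compound 1 gives the second highest of the three numbers in this assay. Its nearest neighbour is compound 2, whose number lies within the scatter of the number of compound 1, so no order between these two is claimed. Compound 3, which carries no substituent on either ring of the shared core, stands far beyond the scatter from compound 1, and its number is the highest of the three.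

Compound 4 `CCc1cccc(-c2cc(Cl)cc(Cl)c2/C=C/[C@@H]2C[C@@H](O)CC(=O)O2)c1` is not yet measured. It differs from compound 1 in one place: 3-ethylphenyl in place of 3,4-dichlorophenyl on an aromatic carbon. The two chloro groups on the ring bearing the vinyl link are kept, as is the lactone portion of the core.

Among the compounds with values here, the data hold no measured pair that isolates this change. Compound 2 shows that a ring of the same kind without chlorine can give a number within the scatter of compound 1, while compound 3 shows that removing all substituents gives a much higher number. Since compound 4 keeps a substituted ring at the same place, the step from compound 1 to compound 4 is expected to be small, if anything a modest rise, as a 1.6-fold higher number from compound 1 to compound 4 (0.20 log units; within the scatter) expresses. For compound 4 the estimate in this assay is 40 nM, with a range of 12 nM to 130 nM.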

Compound 4, half-maximal inhibitory concentration: 44 nM
For compound 4 the middle estimate is 1.1-fold (0.04 log units) below the measured one, within the range that was stated.
By their numbers in this assay, from the lowest: compounds 2, 1 and 4 (each within the scatter of the next, the first and the last beyond it); then compound 3.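

In this assay, within the data shown here, this pair is the first to isolate a change at this aromatic carbon, and it gives a 1.8-fold higher number from compound 1 to compound 4 (0.25 log units; within the scatter) and so does not separate 3-ethylphenyl from 3,4-dichlorophenyl. The position therefore tolerates a ring that carries an ethyl group and no chlorine, at least while the two chloro groups elsewhere in the shared core are kept. Nothing available explains why the two rings give numbers so close together.

Open, from the compounds shown here alone, is whether an amine or a carboxylic acid on this ring, or a chain longer than ethyl, would stay in the same range. Also open, going by these compounds, is whether the same exchange would give a similar step on a core carrying two methyl groups in place of the two chloro groups, as in compound 2.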